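The source may report more compounds than this note shows. Statements on the series, on what has been measured and on what is new or still open speak of the compounds shown alone.

Of the compounds shown here, two built on one shared core have been measured in a functional assay on the whole organism (strain Kunming) for inhibition, with Mus musculus as the target, in the writhing test, at a dose of 40 mg/kg by the oral route; a higher number here means more inhibition at the dose given (going by the name of the read-out), a lower number less inhibition. Compound 1 `CC(=O)Oc1ccc(-c2ccc(F)cc2F)cc1C(=O)Nc1ccc(C)cc1` gives 31%. Compound 2 `CC(=O)Oc1ccc(-c2ccc(F)cc2F)cc1C(=O)Nc1ccccc1Cl` gives 11.7%, the lower of the two numbers. Within the data shown here, the only measured step, a number 19.3 percentage points lower from compound 1 to compound 2 (beyond the scatter), shows that swapping one aromatic ring for another on the amide-type nitrogen can shift the read-out by a modest amount. Compound 3 `CC(=O)Oc1ccc(-c2ccc(F)cc2F)cc1C(=O)NN1CCOCC1` carries a different kind of change at that same place: morpholin-4-yl in place of 2-chlorophenyl on an amide-type nitrogen. Among the measured compounds shown here, no measured step exchanges an aromatic ring for a non-aromatic ring there, so the single step from compound 1 to compound 2 is only a loose guide, and the direction of the expected step in this assay is uncertain. The estimate for compound 3 is 20%, between 5% and 40%. This estimate amounts to an expected step of a number 8.3 percentage points higher from compound 2 to compound 3 (within the scatter).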

Compound 3, a percentage reported as inhibition, in the whole organism at one dose (the size of the read-out at that dose, not a potency): 28.5%
For compound 3 the middle estimate is 8.5 percentage points below the measured one; low and high end bracket the measured number.
By their numbers in this assay, from the lowest: compound 2; then compounds 3 and 1 (each within the scatter of the next).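

In this assay, morpholin-4-yl in place of 2-chlorophenyl on the amide-type nitrogen gives a number 16.8 percentage points higher from compound 2 to compound 3 (beyond the scatter), while morpholin-4-yl in place of 4-methylphenyl gives a number 2.5 percentage points lower from compound 1 to compound 3 (within the scatter). An aromatic ring on this nitrogen is therefore not needed for a number at the level of compound 1, and a non-aromatic ring with two hetero atoms can stand at this place. Nothing available gives a reason for either step.

From the compounds shown here alone, it remains open whether piperidin-1-yl, the same ring with carbon in place of the ring oxygen, or an open-chain group such as dimethylamino would give a similar number at this place. Going by these compounds, a single dose shows the size of the read-out and not a potency, so how these compounds compare at other doses also stays open.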